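This account rests on a few compounds, and the source may have more. Where it says the series, first, only, none or still open, it means among the compounds named here.

Measured so far:
Compound 1, `COc1nc(-c2ccccc2F)ccc1[C@@H](c1ccccc1)[C@@](O)(CCN(C)C)c1cccc2ccccc12`: "nd" (no result reported)
Compound 2, `COc1nc(-c2ccc(F)cc2)ccc1[C@@H](c1ccccc1)[C@@](O)(CCN(C)C)c1cccc2ccccc12`: > 64 ug/mL
Compound 3, `COc1ccc(-c2ccc([C@@H](c3ccccc3)[C@@](O)(CCN(C)C)c3cccc4ccccc34)c(OC)n2)cc1`: > 64 ug/mL

All three compounds share one core and differ only in the aryl group carried on it. Their toxicity was tested in a toxicity assay on HeLa cells (Homo sapiens) for cytotoxicity; on this read-out lower numbers stand for higher toxicity in this test and higher numbers for lower toxicity in this test. For compound 1 no number is available in this assay, recorded as "nd" (no result reported). Compound 2 reached only a limit of this assay, > 64 ug/mL. Compound 3 likewise reached only a limit of this assay, > 64 ug/mL. Among the measured compounds shown here, the single step between measured compounds, a step that the two limits leave unreadable from compound 2 to compound 3, is therefore of unknown size. Compound 3 thus stands at the same limit as compound 2, and the whole evidence the set offers is the limit of > 64 ug/mL in this assay, at which 2 of the 3 values shown sit.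

Compound 4, `COc1nc(-c2ccccc2Cl)ccc1[C@@H](c1ccccc1)[C@@](O)(CCN(C)C)c1cccc2ccccc12`, is not yet measured. It differs from compound 3 by 2-chlorophenyl in place of 4-methoxyphenyl on an aromatic carbon. For the measured compounds named here, no measured step with a readable size bears on this change. What can be said is that both measured values sit at a limit, so compound 4 is expected to land in the same region, with an estimated 70 ug/mL and a range from 35 ug/mL to 140 ug/mL. The expected step that the limit leaves unreadable from compound 3 to compound 4 is therefore estimated to be no larger than the ordinary scatter, and a further limit rather than a number is considered likely.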

Compound 4, half-maximal cytotoxic concentration: > 64 ug/mL
Compound 4: only a limit was reported; the forecaster's own chance of this, stated with the estimate: 70%; the middle value does not contradict the limit.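

In this assay, compound 4 gives only a limit, > 64 ug/mL. Among the compounds shown here, compound 2 and compound 3 also stand at limits, so no step from either to compound 4 can be read. The compounds shown leave open at what concentration any of them becomes toxic to these cells, and whether changing the aryl group matters, with only this to go on: the limit of > 64 ug/mL in this assay, at which 3 of the 4 values shown sit.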